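A few compounds are considered here, and "the series" means these few. Any claim that something is new, unique, unknown or untested is made for them only; others in the source may bear on it.

Compound 1 `Cc1c(C(=O)NCc2ccccc2)[n+]([O-])c2ccccc2[n+]1[O-]` carries an amide on a shared core. In an ADME assay on Vero cells (Chlorocebus sabaeus) for cytotoxicity, read by MTT assay, with a stated time of 72 h (on this read-out lower numbers stand for stronger inhibition and higher numbers for weaker inhibition), compound 1 gives only a limit, > 100 ug/mL. Compound 2 `Cc1c(C(=O)NCc2ccccc2)[n+]([O-])c2cc(Cl)ccc2[n+]1[O-]` adds a chloro group to that core. In this assay compound 2 likewise gives only a limit, > 100 ug/mL. The step that the two limits leave unreadable from compound 1 to compound 2 cannot be sized, because both values sit at the limit of > 100 ug/mL in this assay, at which 2 of the 2 values shown sit. Compound 3 `Cc1c(C(=O)NCc2ccccc2)[n+]([O-])c2cc(Cl)c(Cl)cc2[n+]1[O-]` arises from compound 2 through (chloro in place of hydrogen on an aromatic carbon). Among the measured compounds shown here, only that unreadable step bears on this change, so no direction can be read from it. Compound 3 is expected to give about 100 ug/mL, within 50 ug/mL to 200 ug/mL, a step estimated as a number no higher from compound 2 to compound 3 (the limit leaves the size open).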

Compound 3, half-maximal inhibitory concentration: > 100 ug/mL
Compound 3: only a limit was reported; the forecaster's own chance of this, stated with the estimate: 75%; the middle value lies on the limit itself.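

No new step can be read from compound 2 to compound 3, because the result is again only a limit: the limit of > 100 ug/mL in this assay, at which 3 of the 3 values shown sit.

The compounds shown leave open whether chloro groups on the shared core change the result in this assay at all.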